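The source may report more compounds than this note shows. Statements on the series, on what has been measured and on what is new or still open speak of the compounds shown alone.

Compound 1 `CN(C)CCN1CCN(c2nc(-c3ccccn3)nc3c2CN(Cc2ccc(F)cc2)CC3)CC1` was tested in an assay on A549 cells with Cystic fibrosis transmembrane conductance regulator variant F508del (Homo sapiens) as the target, read by fluorescence, with a stated time of 25 min (a lower number here means a smaller maximal response, a higher number a larger maximal response), where it was recorded as "not active" (no number reported) and so gives no number to anchor a comparison. A second compound from the same series, compound 2 `CC(=O)NCCNc1nc(-c2ccccn2)nc2c1CN(Cc1ccc(F)cc1)CC2`, carries a different side chain on the shared core and gives 44.3% in this assay, which shows that the core itself can produce a measurable response once the side chain is changed.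

The step considered here keeps the side chain of compound 1 and alters only the benzyl group, leading to compound 3 `CC(C)c1ccc(CN2CCc3nc(-c4ccccn4)nc(N4CCN(CCN(C)C)CC4)c3C2)cc1`. The difference between the two is isopropyl in place of fluoro on an aromatic carbon. Within the data shown here, because compound 1 is "not active" (no number reported), there is no starting value against which to set a direction, and no measured pair in this set shows the same change, so the size of the step in this assay cannot be read from the data.

Given that, compound 3 is expected to give about 15% in this assay, within a range from 0% to 40%, with a fair chance that it too is reported only as not active.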

Compound 3, largest response reached (Emax), in percent of the reference or control that the assay uses: "not active" (no number reported)
For compound 3 the study gives words and no number; there is nothing to compare the estimate with.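

In this assay compound 1 gives "not active" (no number reported) and compound 3 gives "not active" (no number reported), so no step can be read for the change from fluoro to isopropyl. Nothing shown here helps to explain this result. The compounds shown leave open whether any other group in place of fluoro would give a measurable response while the side chain of compound 1 stays the same.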